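The source may report more compounds than this note shows. Statements on the series, on what has been measured and on what is new or still open speak of the compounds shown alone.

Measured so far, in a functional assay on CCRF-CEM cells (Homo sapiens) for cytotoxicity, read by sulforhodamine B assay, with a stated time of 48 h; on this read-out higher numbers stand for lower toxicity in this test and lower numbers for higher toxicity in this test:
- compound 1 `ClCc1cccc(Cn2cnc3ncnc(Cl)c32)c1`, 60300 nM
- compound 2 `ClCc1ccc(Cn2cnc3nc(Cl)nc(Cl)c32)cc1`, 66100 nM
- compound 3 `ClCc1ccccc1Cn1cnc2ncnc(Cl)c21`, 8700 nM

Compound 1 stands second highest of the three numbers in this assay. Its nearest neighbour is compound 2, whose number is within the scatter of that of compound 1, so no order can be read between them. For the measured compounds named here, its furthest is compound 3, whose lower number lies beyond the scatter; compound 3 and compound 1 share the same core and differ only in where the chloromethyl group sits on the benzyl ring, though no single step between them is counted here.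

The compound not yet measured is compound 4 `ClCc1cccc(Cn2cnc3nc(Cl)nc(Cl)c32)c1`. It differs from compound 1 in one place: chloro in place of hydrogen on an aromatic carbon. The same kind of change separates compound 2 from the monochloro cores of compound 1 and compound 3, and compound 2 and compound 1 give numbers within the scatter of each other, which does not point to any large effect of the second chloro group, although those two also differ in the benzyl substitution.

On this basis no step beyond the scatter is expected in this assay, and compound 4 is estimated at 50000 nM, in the range from 20000 nM to 120000 nM. The step from compound 1 to compound 4 expected on that estimate is a 1.2-fold lower number from compound 1 to compound 4 (0.08 log units; within the scatter).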

Compound 4, concentration lethal to 50% of the cells: 5490 nM
The estimate for compound 4 lay 9.1-fold (0.96 log units) above the measured number; the measured number lies below the stated range.
By their numbers in this assay, from the lowest: compounds 4 and 3 (each within the scatter of the next); then compounds 1 and 2 (each within the scatter of the next).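

Placing chloro on the aromatic carbon between two ring nitrogen atoms is the first single change that can be read directly in this set, and in this assay it gives an 11-fold lower number from compound 1 to compound 4 (1.04 log units; beyond the scatter), a large step towards higher toxicity in this test. The earlier compounds shown here did not show this: compound 2 carries the same chloro group, with its chloromethyl group elsewhere on the benzyl ring, and gives 66100 nM, so the step holds for this pair and cannot be taken as a general effect of that chloro group. Nothing available here accounts for the size of the step.

With one such step shown, it stays open whether another group on that carbon, such as an amine or a methoxy group, would give a number close to that of compound 1 or to that of compound 4. As far as these compounds go, it is also open whether chloro at this position would bring any further step on the benzyl arrangement of compound 3, which gives 8700 nM without it.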